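Aryl Swap on the Hydrazone Arm of a Shared Core

A few compounds are considered here, and "the series" means these few. Any claim that something is new, unique, unknown or untested is made for them only; others in the source may bear on it.

The measured compounds are:
compound 1, `COc1ccc(OC)c(/C=N/NC(=O)Nc2ccc(Oc3ccnc(-c4nncn4CCN(C)C)c3)c(F)c2)c1`, which in a functional assay on A549 cells (Homo sapiens) for cytotoxicity, read by MTT assay, with a stated time of 72 h (a lower number here means a stronger inhibitor, a higher number a weaker inhibitor), gives 1950 nM
compound 2, `Cc1cc(/C=N/NC(=O)Nc2ccc(Oc3ccnc(-c4nncn4CCN(C)C)c3)c(F)c2)cc(C)c1O`, which in this assay gives 1640 nM
compound 3, `CN(C)CCn1cnnc1-c1cc(Oc2ccc(NC(=O)N/N=C/c3c(Cl)cccc3Cl)cc2F)ccn1`, which in this assay gives 1410 nM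

Compound 3 has the lowest number of the three, but its steps to the others are small: a 1.4-fold lower number from compound 1 to compound 3 (0.14 log units; within the scatter) and a 1.2-fold lower number from compound 2 to compound 3 (0.07 log units; within the scatter), both within the scatter, so no order among compounds 1, 2 and 3 can be claimed. The three differ only in the aryl group on the carbon with a double bond to nitrogen, and a 1.2-fold lower number from compound 1 to compound 2 (0.08 log units; within the scatter) shows that exchanging one such aryl for another barely moves the number.

Compound 4, `COc1cc(/C=N/NC(=O)Nc2ccc(Oc3ccnc(-c4nncn4CCN(C)C)c3)c(F)c2)cc(OC)c1OC`, is not yet measured. It differs from compound 3 in the same way: 3,4,5-trimethoxyphenyl in place of 2,6-dichlorophenyl on a carbon with a double bond to nitrogen. All three measured steps at this position are within the scatter, so the step from compound 3 to compound 4 is expected to be small as well, with no direction beyond the scatter, estimated as a 1.1-fold higher number from compound 3 to compound 4 (0.05 log units; within the scatter).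

For compound 4 in this assay the expected value is 1600 nM, within a range from 600 nM to 4500 nM.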

Compound 4, half-maximal inhibitory concentration: > 100000 nM
Compound 4: a limit, no number; the forecaster's own chance of this, stated with the estimate: 5%; middle value at least 62-fold (1.79 log units) away from the limit.
By their numbers in this assay, from the lowest: compounds 3, 2 and 1 (each within the scatter of the next). At a limit, above all of these: compound 4.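

For the compounds shown here, until this result, every exchange of aryl group on the carbon with a double bond to nitrogen had stayed within the scatter, so the position looked tolerant of whichever aryl it carried. The 3,4,5-trimethoxyphenyl group ends that picture, with an at least 70-fold higher number from compound 3 to compound 4 (1.85 log units; beyond the scatter), an at least 60-fold higher number from compound 2 to compound 4 (1.78 log units; beyond the scatter) and an at least 51-fold higher number from compound 1 to compound 4 (1.70 log units; beyond the scatter), so the position is not indifferent to the aryl group after all. Methoxy groups alone do not go with this loss, since compound 1, with its 2,5-dimethoxyphenyl group, stays within the scatter of compound 2 and compound 3, and compound 4 reads as a limit, not a number: the limit of > 100000 nM in this assay, at which 1 of the 4 values shown sits.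

What the compounds shown leave open is whether the loss belongs to the full 3,4,5-trimethoxyphenyl pattern or to a part of it, which a 3,5-dimethoxyphenyl or a 4-methoxyphenyl group on the same carbon could separate. From the compounds shown here alone, how far past its limit compound 4 lies also stays open, as does the effect of an aryl group carrying an amine or a carboxylic acid at this position.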